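This account rests on a few compounds, and the source may have more. Where it says the series, first, only, none or still open, it means among the compounds named here.

Compound 1 has the structure `COc1cnc(-c2ccccn2)nc1C1CCCC1`. In an in vitro ADME assay on microsomes from liver (Rattus norvegicus) for metabolic stability, read by LC-MS, tested at 0.05 uM (on this read-out lower numbers stand for slow clearance and higher numbers for fast clearance), compound 1 gives > 1000 mL/min/kg, and this is a limit of the assay rather than a measured number, as the limit of > 1000 mL/min/kg in this assay, at which 1 of the 3 values shown sits, shows. Two other compounds with the shared core have been measured. Compound 2, with the structure `COc1cnc(-c2ccccn2)nc1NCc1ccccc1F`, gives 413 mL/min/kg in this assay. Compound 3, with the structure `COc1cnc(-c2ccccn2)nc1NC(C)c1ccccc1`, gives 420 mL/min/kg in this assay, and the values of compound 2 and compound 3 sit within the scatter of each other.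

Compound 4, with the structure `COc1cnc(-c2ccccn2)nc1NC1CCCC1`, has not yet been measured. It differs from compound 1 by cyclopentylamino in place of cyclopentyl on an aromatic carbon. Within the data shown here, no measured pair of compounds differs in exactly this way, so the size of the step has to be guessed. The step from compound 1 to compound 4 is expected to be a move toward slower clearance, an at least 2.0-fold lower number from compound 1 to compound 4 (0.30 log units; that floor lies within the scatter), beyond the usual scatter. Compound 2 gives 413 mL/min/kg and compound 3 gives 420 mL/min/kg, both measured as numbers. The expectation for compound 4 takes its bearings from these two values. Compound 4 is therefore estimated at 500 mL/min/kg, with a range from 200 mL/min/kg to 1200 mL/min/kg, though the assay may again report only a limit.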

Compound 4, clearance: 202 mL/min/kg
Beside the measured number, compound 4's estimate is 2.5-fold (0.39 log units) above it; the measured number falls inside the stated range.
By their numbers in this assay, from the lowest: compound 4; then compounds 2 and 3 (each within the scatter of the next). At a limit, above all of these: compound 1.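

Keeping the cyclopentyl ring and adding only a nitrogen, so that cyclopentylamino replaces cyclopentyl on an aromatic carbon of the shared core, gives an at least 4.9-fold lower number from compound 1 to compound 4 (0.69 log units; beyond the scatter) in this assay, a clear move toward slower clearance. Among these compounds, compound 2 and compound 3 also carry a nitrogen at this position, but each has a different group on it and no partner without the nitrogen; only this new pair isolates the change, while compound 4, at 202 mL/min/kg, sits within the scatter of compound 2. The true size of the step remains unknown, and the printed figure is only a floor, because compound 1 stands at a limit of the assay: the limit of > 1000 mL/min/kg in this assay, at which 1 of the 4 values shown sits.

The compounds shown leave open whether the nitrogen itself matters or the hydrogen it carries, a question that a cyclopentyloxy group or an N-methyl-N-cyclopentylamino group at the same position could help to settle. They also leave open whether the same change holds for other groups, for instance a benzyl group set directly on the core and compared with the benzylamino group.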